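This account rests on a few compounds, and the source may have more. Where it says the series, first, only, none or still open, it means among the compounds named here.

Working notes on the carbamate series.

Within the data shown here, compound 3 `CCCCCCOC(=O)Nc1ccc([Se]C#N)cc1` gives 10700 nM in a functional assay on HT-29 cells (Homo sapiens) for cytotoxicity, read by MTT assay, with a stated time of 72 h (on this read-out lower numbers stand for stronger inhibition of growth and higher numbers for weaker inhibition of growth), the second highest of the three numbers so far. Its nearest neighbour is compound 2 `N#C[Se]c1ccc(NC(=O)Oc2ccccc2)cc1` with 11700 nM, and the step of a 1.1-fold lower number from compound 2 to compound 3 (0.04 log units; within the scatter) stays within the scatter. Furthest is compound 1 `CCOC(=O)Nc1ccc([Se]C#N)cc1` with 9300 nM, where a 1.2-fold higher number from compound 1 to compound 3 (0.06 log units; within the scatter) also stays within the scatter, as does a 1.3-fold higher number from compound 1 to compound 2 (0.10 log units; within the scatter).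

Compound 4 `CCCCOC(=O)Nc1ccc([Se]C#N)cc1` is the next member. The change from compound 3 is hydrogen in place of ethyl on a saturated chain carbon, four bonds along the chain from an oxygen next to a carbonyl group. The step that bears on it most directly is a 1.2-fold higher number from compound 1 to compound 3 (0.06 log units; within the scatter), since it also alters the chain on the oxygen next to the carbonyl and produced nothing beyond the scatter; the two steps that swap ethyl, phenyl and hexyl on that oxygen point the same way. For compound 4 the step of a 1.1-fold lower number from compound 3 to compound 4 (0.03 log units; within the scatter) is therefore expected to be within the scatter, with no direction. Compound 4 is estimated at 10000 nM, with a range from 5000 nM to 20000 nM.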

Compound 4, concentration for 50% growth inhibition: 8100 nM
For compound 4 the middle estimate is 1.2-fold (0.09 log units) above the measured one; low and high end bracket the measured number.
By their numbers in this assay, from the lowest: compounds 4, 1, 3 and 2 (each within the scatter of the next).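

In this assay, the chain on the oxygen next to a carbonyl group now has a middle member, and hydrogen in place of ethyl at the position four bonds along that chain gives a 1.3-fold lower number from compound 3 to compound 4 (0.12 log units; within the scatter). Butyl fits the flat picture from the other two sides as well, with a 1.1-fold lower number from compound 1 to compound 4 (0.06 log units; within the scatter) and a 1.4-fold lower number from compound 2 to compound 4 (0.16 log units; within the scatter), so ethyl, butyl, hexyl and phenyl on this oxygen all stay within the scatter of one another, and none of the four compounds goes against this. No measurement bears on why this chain makes so little difference here.

Open, from the compounds shown here alone, is whether a longer chain such as decyl, or a chain ending in an amine or a carboxylic acid, would move the number beyond the scatter. Also open, going by these compounds, is whether any change outside this chain would do so.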